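A few compounds are considered here, and "the series" means these few. Any claim that something is new, unique, unknown or untested is made for them only; others in the source may bear on it.

Among the measured compounds shown here, compound 3 `COc1cc2c(Oc3ccc(NC(=O)c4cn(-c5ccccc5OC(F)(F)F)cn4)cc3F)ccnc2cc1OCCCN1CCC(C)CC1` gives 150 nM in a functional assay on MKN-45 cells (Homo sapiens) for cytotoxicity, read by MTT assay, with a stated time of 72 h (a higher number here means a weaker inhibitor, a lower number a stronger inhibitor), the lowest of the three numbers measured so far. Compound 1 `COc1cc2c(Oc3ccc(NC(=O)c4cn(-c5cc(C)ccc5C)cn4)cc3F)ccnc2cc1OCCCN1CCN(C)CC1` gives 650 nM in this assay, and compound 2 `COc1cc2c(Oc3ccc(NC(=O)c4cn(-c5cc(C)ccc5C)cn4)cc3F)ccnc2cc1OCCCN1CCCCC1` gives 830 nM. Compound 4 `COc1cc2c(Oc3ccc(NC(=O)c4cn(-c5cc(C)ccc5C)cn4)cc3F)ccnc2cc1OCCCN1CCC(C)CC1` is made from compound 3 by one change: 2,5-dimethylphenyl in place of 2-(trifluoromethoxy)phenyl on an aromatic nitrogen. For the measured compounds named here, no measured pair isolates this change, so its effect is unknown. Compound 4 shares its 2,5-dimethylphenyl group with compounds 1 and 2, and its 4-methylpiperidin-1-yl tail with compound 3. Going by the values given here, the only measured step, a 1.3-fold higher number from compound 1 to compound 2 (0.11 log units; within the scatter), shows that swapping the basic tail between two saturated rings barely moves the number, which suggests compound 3 may owe its lower number mostly to its 2-(trifluoromethoxy)phenyl group. On that basis compound 4 is expected to move back towards compounds 1 and 2, with a step of a 3.3-fold higher number from compound 3 to compound 4 (0.52 log units; beyond the scatter) to a higher number. The estimate for compound 4 in this assay is 500 nM, within a range from 200 nM to 1500 nM.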

Compound 4, half-maximal inhibitory concentration: 5650 nM
The estimate for compound 4 lay 11-fold (1.05 log units) below the measured number; the measured number lies above the stated range.
By their numbers in this assay, from the lowest: compound 3; then compounds 1 and 2 (each within the scatter of the next); then compound 4.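

In this assay, the group on the aromatic nitrogen proves to matter a great deal: 2,5-dimethylphenyl in place of 2-(trifluoromethoxy)phenyl gives a 38-fold higher number from compound 3 to compound 4 (1.58 log units; beyond the scatter) and is the largest step seen here. The tail also matters more than the earlier pair suggested, since with 2,5-dimethylphenyl held fixed, adding a methyl on a saturated ring carbon gives a 6.8-fold higher number from compound 2 to compound 4 (0.83 log units; beyond the scatter) and 4-methylpiperidin-1-yl in place of 4-methylpiperazin-1-yl gives an 8.7-fold higher number from compound 1 to compound 4 (0.94 log units; beyond the scatter) in the same direction. Nothing available explains why these changes move the number.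

Still open, from the compounds shown here alone, is whether the piperidine and piperazine tails would behave the same way alongside 2-(trifluoromethoxy)phenyl. It is also unknown where a plain phenyl or a 2-methoxyphenyl group on that nitrogen would fall.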